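The compounds below may be only part of what the source reports. "The series", "measured", "known", "first", "only" and "open" are said of these compounds alone.

Measured in an ADME assay on BHK-21 cells (Mesocricetus auratus) for cytotoxicity, with a stated time of 3 days; on this read-out lower numbers stand for higher toxicity in this test and higher numbers for lower toxicity in this test:
Compound 2, `O=C(CCSc1nnc(-c2ccncc2)s1)Nc1ccc(Cl)cc1`: 8210 nM
Compound 1, `CC(Sc1nnc(-c2ccncc2)s1)C(=O)Nc1ccc(Cl)cc1Cl`: > 50000 nM, a limit of the assay and not a number

Within the data shown here, compound 2 holds the only actual number; the one other value shown is a limit. Compound 1 sits at the limit of > 50000 nM in this assay, at which 1 of the 2 values shown sits, which marks the edge of the assay rather than a measured value. Compound 3, `O=C(CCSc1nnc(-c2ccncc2)s1)Nc1ccccc1`, has not been measured. It differs from compound 2 by hydrogen in place of chloro on an aromatic carbon, para to a large group, so that 4-chlorophenyl becomes phenyl. Among the measured compounds shown here, no pair of measured compounds carries this single change, so the size of the step in this assay is uncertain; a step from compound 2 to compound 3 that stays within the usual scatter, or at most a modest move toward lower toxicity in this test, appears most likely. Compound 3 is expected to give 14000 nM, between 5000 nM and 50000 nM, which amounts to an expected step of a 1.7-fold higher number from compound 2 to compound 3 (0.23 log units; within the scatter).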

Compound 3, half-maximal cytotoxic concentration: > 50000 nM
Compound 3: only a limit was reported; the forecaster's own chance of this, stated with the estimate: 30%; middle value at least 3.5-fold (0.55 log units) away from the limit.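

In this assay, among these compounds, the change from 4-chlorophenyl to phenyl gives an at least 6.0-fold higher number from compound 2 to compound 3 (0.78 log units; beyond the scatter), the first single change whose size can be read, and it lies beyond the scatter. The chloro on the aromatic carbon, para to a large group, therefore matters here: with it, compound 2 shows toxicity within the range of the test, and with hydrogen in its place that toxicity no longer registers. Compound 3 gives > 50000 nM, a limit of the assay and not a number, so the step is only a minimum and its full size remains unknown: the limit of > 50000 nM in this assay, at which 2 of the 3 values shown sit.

On these data alone, whether a fluoro, methyl or methoxy group at the same place would behave like chloro or like hydrogen stays open. So does the reading that a longer chain in compound 2 would give.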